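The source may report more compounds than this note shows. Statements on the series, on what has been measured and on what is new or still open speak of the compounds shown alone.

Measured so far:
compound 1, `O=C(CCl)Nc1cccc(Cn2nc(-c3ccc(Oc4ccccc4)cc3)cc2CO)c1`, 400 nM
compound 2, `CCOC(=O)c1cc(-c2ccc(Oc3ccccc3)cc2)nn1Cc1cccc(NC(=O)CCl)c1`, 400 nM
compound 3, `C=CC(=O)Nc1cccc(Cn2nc(-c3ccc(Oc4ccccc4)cc3)cc2C(=O)O)c1`, 28500 nM

In a functional assay on Z-138 cells (Homo sapiens) for inhibition, read by luminescence and CellTiter-Glo, with a stated time of 72 h (on this read-out lower numbers stand for stronger inhibition and higher numbers for weaker inhibition), compound 2 gives 400 nM, level with compound 1 and together with it the lowest of the three numbers; compound 3 sits far higher at 28500 nM. Within the data shown here, the only single-point step measured, no change at the digits printed from compound 1 to compound 2 (within the scatter), concerns the group on the core rather than the group now in question, so it says little about what follows.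

Compound 4, `C=CC(=O)Nc1ccc(Cn2nc(-c3ccc(Oc4ccccc4)cc3)cc2C(=O)OCC)cc1`, differs from compound 2 in that (4-((vinylcarbonyl)amino)phenyl in place of 3-(((chloromethyl)carbonyl)amino)phenyl on a saturated chain carbon bound to an aromatic nitrogen). Among the measured compounds shown here, no measured pair isolates this change. Compound 3 carries the vinylcarbonyl amide too, but also a carboxylic acid where compound 2 has the ethoxycarbonyl group, so its weak value cannot be laid on the amide alone. Because compound 3 gives 28500 nM, the expectation for compound 4 is a weakening step, a 3.0-fold higher number from compound 2 to compound 4 (0.48 log units; beyond the scatter), with wide uncertainty. The estimate for compound 4 in this assay is 1200 nM, within 200 nM to 10000 nM.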

Compound 4, half-maximal inhibitory concentration: 12500 nM
Estimate against measurement, compound 4: 10-fold (1.02 log units) below; the measured number lies above the stated range.
By their numbers in this assay, from the lowest: compounds 1 and 2 (each within the scatter of the next); then compound 4; then compound 3.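

In this assay, the group on the saturated chain carbon bound to an aromatic nitrogen proves far from neutral: with the ethoxycarbonyl group held constant, replacing 3-(((chloromethyl)carbonyl)amino)phenyl by 4-((vinylcarbonyl)amino)phenyl gives a 31-fold higher number from compound 2 to compound 4 (1.49 log units; beyond the scatter), a large step. The earlier compounds shown here offered no clean comparison at this place, and this pair shows that the weak value of compound 4 arises without any carboxylic acid on the core. No measurement shown gives the reason for the loss.

This single step changes both the reactive amide and its ring position, so the contribution of each stays unresolved. A 4-(((chloromethyl)carbonyl)amino)phenyl group on the same ester core would separate the two, and a plain 4-aminophenyl group would test how much the amide acyl group matters at all.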